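Hydroxy for 2-aminophenyl on an amide-type nitrogen

This account rests on a few compounds, and the source may have more. Where it says the series, first, only, none or still open, it means among the compounds named here.

In a functional assay on MV4-11 cells (Homo sapiens) for antiproliferative activity, read by CCK-8 assay, with a stated time of 72 h (on this read-out higher numbers stand for weaker inhibition and lower numbers for stronger inhibition), compound 1 `Cn1cc(-c2ccccc2Oc2ccccc2)c2cc(C(=O)NCCCC(=O)NO)[nH]c2c1=O` gives 380 nM while compound 2 `Cn1cc(-c2ccccc2Oc2ccccc2)c2cc(C(=O)NCc3ccc(C(=O)Nc4ccccc4N)cc3)[nH]c2c1=O` gives 80 nM and so holds the lower of the two numbers, the stronger inhibition of the pair. Compound 3 `Cn1cc(-c2ccccc2Oc2ccccc2)c2cc(C(=O)NCc3ccc(C(=O)NO)cc3)[nH]c2c1=O` has not yet been measured and differs from compound 2 in one place: hydroxy in place of 2-aminophenyl on an amide-type nitrogen, a difference counted as hydroxy in place of 2-aminophenyl on an amide-type nitrogen in full. For the measured compounds named here, no measured pair isolates this change. Going by the values given here, the only guide is that compound 1 also ends in hydroxycarbamoyl and stands at 380 nM on a different chain. A modest move toward weaker inhibition is therefore expected, an estimated 2.1-fold higher number from compound 2 to compound 3 (0.33 log units; beyond the scatter) in this assay on this reasoning. For compound 3 the estimate is 170 nM with a range from 45 nM to 600 nM expected for it.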

Compound 3, half-maximal inhibitory concentration: 570 nM
For compound 3 the middle estimate is 3.4-fold (0.53 log units) below the measured one, and the stated range covers the measured number.
By their numbers in this assay, from the lowest: compound 2; then compounds 1 and 3 (each within the scatter of the next).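

In this assay the step from 2-aminophenyl to hydroxy on the amide-type nitrogen, now read directly, is a 7.1-fold higher number from compound 2 to compound 3 (0.85 log units; beyond the scatter) and it favours the 2-aminophenyl end on this benzyl-linked chain. Placing 4-(hydroxycarbamoyl)phenyl in place of 2-(hydroxycarbamoyl)ethyl on the saturated chain carbon bound to an amide-type nitrogen gives a 1.5-fold higher number from compound 1 to compound 3 (0.18 log units; within the scatter) and so does not separate the two hydroxycarbamoyl compounds, which shows that with this end group the two chains cannot be told apart here. No measurement at hand gives a reason for the gap between the two end groups.

On these data alone, whether 2-aminophenyl would hold the same lead on the chain of compound 1 stays open. So does how a carboxylic acid or a longer saturated chain would read at this position.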